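Swapping the Nitrile for a Butyl Amide on the Chain

The source may report more compounds than this note shows. Statements on the series, on what has been measured and on what is new or still open speak of the compounds shown alone.

Measured so far:
- compound 1 `CC(C)(N)C(=O)N[C@H](COCc1ccccc1)c1nnnn1CCCCC#N` gives 3120 nM
- compound 2 `CC(C)(N)C(=O)N[C@H](COCc1ccccc1)c1nnnn1CCC#N` gives 2940 nM

Both numbers come from an assay on isolated protein for displacement of a labelled ligand from growth hormone secretagogue receptor type 1 (Homo sapiens), with a stated time of 1 h; a lower number here means a stronger inhibitor, a higher number a weaker inhibitor. Among the measured compounds shown here, compound 2 has the lower of the two values, but the only step between them, a 1.1-fold lower number from compound 1 to compound 2 (0.03 log units; within the scatter), lies within the scatter, so no real order between compound 1 and compound 2 can be read from these numbers.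

Compound 3 `CCCCNC(=O)CCn1nnnc1[C@@H](COCc1ccccc1)NC(=O)C(C)(C)N` has not yet been measured. It differs from compound 2 by butylcarbamoyl in place of cyano on a saturated chain carbon, two bonds along the chain from an aromatic nitrogen. For the measured compounds named here, the single measured step shortened the chain while keeping the nitrile at its end and changed nothing beyond the scatter; no measured pair shows what happens when the nitrile itself is exchanged for an amide. The expectation therefore rests on a thin basis. Compound 3 is expected to give 2200 nM in this assay, within a range of 600 nM to 8000 nM. That estimate corresponds to a step of a 1.3-fold lower number from compound 2 to compound 3 (0.13 log units; within the scatter), which is not expected to stand out clearly from the scatter.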

Compound 3, inhibition constant: 2190 nM
Beside the measured number, compound 3's estimate is 1.0-fold (0.00 log units) above it, within the range that was stated.
By their numbers in this assay, from the lowest: compounds 3, 2 and 1 (each within the scatter of the next).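

In this assay, replacing the nitrile with butylcarbamoyl on a saturated chain carbon, two bonds along the chain from an aromatic nitrogen, gives a 1.3-fold lower number from compound 2 to compound 3 (0.13 log units; within the scatter), and the same comparison against the longer nitrile-bearing chain gives a 1.4-fold lower number from compound 1 to compound 3 (0.15 log units; within the scatter). The earlier pair varied only the chain length with the nitrile kept in place, whereas these steps exchange the end group itself: butylcarbamoyl is a much larger group than cyano, contains a carbonyl and brings a hydrogen-bond donor that cyano lacks, yet neither step stands out from the scatter, so no order can be read among the three compounds. No independent evidence is available to explain why the numbers remain so close.

The compounds shown leave open whether a different end group on this chain, such as an amine or a carboxylic acid, would move the number beyond the scatter. They also leave open whether the butyl part of the amide matters, which a methyl amide or an amide with a longer chain could test.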